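The compounds below may be only part of what the source reports. "The series", "measured", "known", "first", "only" and "open" are said of these compounds alone.

In a functional assay on PC-3 cells (Homo sapiens) for antiproliferative activity, read by MTT assay, with a stated time of 72 h (on this read-out higher numbers stand for weaker inhibition and lower numbers for stronger inhibition), compound 1 (`O=C(N/N=C/c1ccc([N+](=O)[O-])cc1)Nc1ccc(Oc2ccnc3[nH]ccc23)c(F)c1`) gives 150 nM, compound 2 (`O=C(N/N=C/c1ccc(F)cc1Cl)Nc1ccc(Oc2ccnc3[nH]ccc23)c(F)c1`) gives 3 nM, and compound 3 (`O=C(N/N=C/c1ccc([N+](=O)[O-])cc1)Nc1ccc(Oc2ccnc3[nH]ccc23)cc1`) gives 28100 nM, the highest number of the three. Compound 4 (`O=C(N/N=C/c1ccc(O)cc1Br)Nc1ccc(Oc2ccnc3[nH]ccc23)cc1`) has not yet been measured. It differs from compound 3 at one place, on a carbon with a double bond to nitrogen: 2-bromo-4-hydroxyphenyl in place of 4-nitrophenyl on a carbon with a double bond to nitrogen.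

Among the measured compounds shown here, no measured step shows this exact exchange. The closest is a 50-fold lower number from compound 1 to compound 2 (1.70 log units; beyond the scatter), which also removes 4-nitrophenyl from that place, although it brings in 2-chloro-4-fluorophenyl and occurs with the fluoro still present. The other measured step, a 190-fold higher number from compound 1 to compound 3 (2.27 log units; beyond the scatter), puts hydrogen in place of that fluoro, and compound 4 keeps this hydrogen. For the measured compounds named here, no measured pair tests the exchange on that background, so the size of the step remains uncertain. A large step to a lower number is nevertheless expected in this assay, somewhat smaller than the closest step. The expected change is a 28-fold lower number from compound 3 to compound 4 (1.45 log units; beyond the scatter). For compound 4 the estimate is 1000 nM, with an expected range of 100 nM to 10000 nM.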

Compound 4, half-maximal inhibitory concentration: "not active" (no number reported)
For compound 4 the study gives words and no number; there is nothing to compare the estimate with.
By their numbers in this assay, from the lowest: compound 2; then compound 1; then compound 3.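

In this assay, among the compounds shown here, compound 4 is reported only as "not active", with no number, so no step from compound 3 to compound 4 can be read. No supporting data bear on this result. The compounds shown leave open how 2-bromo-4-hydroxyphenyl would read with the fluoro of compound 1 present.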